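Methyl in Place of Hydrogen in a Paw Edema Series

A few compounds are considered here, and "the series" means these few. Any claim that something is new, unique, unknown or untested is made for them only; others in the source may bear on it.

Of the compounds shown here, three have so far been tested in a functional assay on the whole organism (strain Wistar Albino) for inhibition, with Rattus norvegicus as the target, read by paw edema, with a stated time of 3 h, at a dose of 20 mg/kg; a higher number here means more inhibition at the dose given (going by the name of the read-out), a lower number less inhibition. Compound 1 `COc1ccc(Cl)c(-c2nnc3sc(Cc4c[nH]c5ccc(OC)cc45)nn23)c1` gives 21.4%. Compound 3 `COc1ccc(Cl)c(-c2nnc3sc(Cc4c(C)[nH]c5ccc(OC)cc45)nn23)c1` differs from compound 1 only by methyl in place of hydrogen on an aromatic carbon, and in this assay compound 3 gives 26.1%. The step from compound 1 to compound 3 is a number 4.7 percentage points higher from compound 1 to compound 3 (within the scatter), so the two numbers cannot be told apart with confidence.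

Compound 2 `COc1ccc2[nH]cc(Cc3nn4c(Cc5ccc(OC)c(OC)c5)nnc4s3)c2c1` is built on a different core; the difference between the two cores is not broken down here. In this assay compound 2 gives 19.1%, a value that sits within the scatter of both compound 1 and compound 3.

Compound 4 `COc1ccc2[nH]c(C)c(Cc3nn4c(Cc5ccc(OC)c(OC)c5)nnc4s3)c2c1` is not yet measured. It differs from compound 2 by methyl in place of hydrogen on an aromatic carbon, the same kind of change as that made from compound 1 to compound 3, with the place described in the same words. Because the earlier step was a number 4.7 percentage points higher from compound 1 to compound 3 (within the scatter), a step of similar size, a number 4.4 percentage points higher from compound 2 to compound 4 (within the scatter), is expected from compound 2 to compound 4. On that basis compound 4 is estimated to give 23.5%, most likely between 14% and 33%.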

Compound 4, a percentage reported as inhibition, in the whole organism at one dose (the size of the read-out at that dose, not a potency): 21.4%
The estimate for compound 4 lay 2.1 percentage points above the measured number; low and high end bracket the measured number.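

On the core shared by compound 2 and compound 4, methyl in place of hydrogen on an aromatic carbon gives, in this assay, a number 2.3 percentage points higher from compound 2 to compound 4 (within the scatter), so these two compounds cannot be told apart with confidence. Set beside the same change on the core of compound 1, the new step does not differ from the earlier one, so nothing here separates the two cores in their response to the methyl: the same change on two cores in this assay, a number 4.7 percentage points higher (within the scatter) from compound 1 to compound 3 and a number 2.3 percentage points higher (within the scatter) from compound 2 to compound 4, 2.4 percentage points apart, within the scatter of two such steps. Within the data shown here, this does not show that the methyl truly raises the number on either core: each step on its own lies within the scatter, and only two pairs are at hand.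

The compounds shown carry only hydrogen or methyl at this place, so it remains open what a longer chain, an amine or a carboxylic acid would do there. Going by these compounds, it also remains open how these compounds would compare at other doses or at other times.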